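Spiro-fused series: cytotoxicity toward normal liver cells

A few compounds are considered here, and "the series" means these few. Any claim that something is new, unique, unknown or untested is made for them only; others in the source may bear on it.

Measured compounds:
compound 1, `CCOc1ccccc1-n1nncc1CN1C(=O)C2(C(C#N)=C(N)Oc3c2c2nc4ccccc4nc2c2ccccc32)c2ccccc21`, in an ADME assay on L02 cells (Homo sapiens) for antiproliferative activity, read by MTT assay, with a stated time of 48 h; a higher number here means a weaker inhibitor, a lower number a stronger inhibitor: > 50000 nM
compound 2, `COc1ccccc1-n1nncc1CN1C(=O)C2(C(C#N)=C(N)Oc3c(N)cc4nc5ccccc5nc4c32)c2ccccc21`, in this assay: > 50000 nM

Compound 1 returns only a limit of this assay, > 50000 nM, not a number. Compound 2 also returns only a limit, > 50000 nM. Going by the values given here, both values shown sit at the limit of > 50000 nM in this assay, at which 2 of the 2 values shown sit, so no ordering of compound 1 against compound 2 can be drawn from these numbers; where compound 2 stands is simply at the limit, together with the one other value shown.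

Compound 3, `N#CC1=C(N)Oc2c(N)cc3nc4ccccc4nc3c2C12C(=O)N(Cc1cnnn1-c1ccc(F)c(Cl)c1)c1ccccc12`, has not been measured. Relative to compound 2 the change is 3-chloro-4-fluorophenyl in place of 2-methoxyphenyl on an aromatic nitrogen. Among the compounds with values here, no step between two measured compounds is available in this assay, so there is no measured basis for a direction. The expectation is that the change produces no step beyond the scatter and that compound 3, like compound 2, is reported only as a limit. Compound 3 is estimated at 50000 nM, with a range from 20000 nM to 100000 nM. The expected step of a number no higher from compound 2 to compound 3 (the limit leaves the size open) is therefore essentially nil.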

Compound 3, half-maximal inhibitory concentration: > 50000 nM
Compound 3: a limit, no number; the forecaster's own chance of this, stated with the estimate: 85%; the middle value lies on the limit itself.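

In this assay compound 3 gives > 50000 nM, a limit and not a number. No step from compound 2 to compound 3 can be read, because both compounds stand at a limit: the limit of > 50000 nM in this assay, at which 3 of the 3 values shown sit.

The compounds shown leave open whether 3-chloro-4-fluorophenyl and 2-methoxyphenyl differ at all in this assay.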